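One Added Carbon Across Two Related Cores

The source may hold more compounds than are shown below. What is called first, only, known or untested is meant among the compounds shown, and "the series" means these compounds.

Of the compounds shown here, three have been measured in an ADME assay for pharmacokinetics, at 37 degrees C, at pH 7.4; on this read-out higher numbers stand for a longer-lived compound and lower numbers for a shorter-lived compound. Compound 1 `CCC/C(=N/S(=O)(=O)c1ccc(C)cc1)OC` gives 2.42 h, and compound 2 `CCCC/C(=N/S(=O)(=O)c1ccc(C)cc1)OC` gives 2.67 h. The change between them is methyl in place of hydrogen on a saturated chain carbon, three bonds along the chain from a carbon with a double bond to nitrogen and its step is a 1.1-fold higher number from compound 1 to compound 2 (0.04 log units; within the scatter). Compound 3 `CCO/C(=N\S(=O)(=O)c1ccc(C)cc1)c1ccccc1` gives 2.92 h; its value and those of compounds 1 and 2 all sit within the scatter of one another, so no order among the three can be read. The difference between the core of compound 1 and the core of compound 3 is not broken down here.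

Compound 4 `CCCO/C(=N\S(=O)(=O)c1ccc(C)cc1)c1ccccc1` has not yet been tested in this assay. It differs from compound 3 by methyl in place of hydrogen on a saturated chain carbon, two bonds along the chain from an oxygen on an unsaturated carbon. Within the data shown here, this is the same kind of change as the one from compound 1 to compound 2, though the surroundings differ: in the earlier pair the place is three bonds along the chain from a carbon with a double bond to nitrogen, while here it is two bonds along the chain from an oxygen on an unsaturated carbon. Because the earlier step was a 1.1-fold higher number from compound 1 to compound 2 (0.04 log units; within the scatter), the step from compound 3 to compound 4 is expected to be a 1.0-fold higher number from compound 3 to compound 4 (0.01 log units; within the scatter). Compound 4 is therefore estimated at 3 h, within 1.8 h to 5 h.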

Compound 4, half-life: 2.92 h
Beside the measured number, compound 4's estimate is 1.0-fold (0.01 log units) above it, within the range that was stated.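

In this assay, the change from ethoxy to propoxy gives no change at the digits printed from compound 3 to compound 4 (within the scatter). Set beside the same added methyl on the other core, the new step shows no difference that can be read: the same change on two cores in this assay, a 1.1-fold higher number (0.04 log units; within the scatter) from compound 1 to compound 2 and no change at the digits printed (within the scatter) from compound 3 to compound 4, 1.1-fold (0.04 log units) apart, within the scatter of two such steps. On these two pairs the change therefore carries from one core to the other with a similar small outcome, but both steps lie within the scatter, the methyl enters at a different place on each core, and two pairs set no rule for the series, so this does not show that a larger effect would carry over in the same way.

The compounds shown leave open whether a longer chain, or an amine or a carboxylic acid at the end of the chain, would move the half-life beyond the scatter on either core. They also leave open how much of any such step would depend on the core that carries it.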